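Adding Methoxy to the End of Compound 2

A few compounds are considered here, and "the series" means these few. Any claim that something is new, unique, unknown or untested is made for them only; others in the source may bear on it.

Compound 1 `CN(C)c1ccc(-c2ccc(-c3ccc(-c4nc5ccccc5[nH]4)cc3)cc2)cc1`: 100000 nM
Compound 2 `Oc1cccc2[nH]c(-c3ccc(-c4ccc(-c5ccccc5)cc4)cc3)nc12`: 35600 nM

Both values come from a functional assay on ZR-75-1 cells (Homo sapiens) for inhibition, read by sulforhodamine B assay; on this read-out higher numbers stand for weaker inhibition of growth and lower numbers for stronger inhibition of growth. Compound 2 has the lower of the two numbers, and compound 1 stands above it by more than the usual scatter. Compound 3 `COc1ccc(-c2ccc(-c3ccc(-c4nc5c(O)cccc5[nH]4)cc3)cc2)cc1` departs from compound 2 in one place: methoxy in place of hydrogen on an aromatic carbon. This puts methoxy in place of hydrogen on an aromatic carbon, para to a large group, so that phenyl becomes 4-methoxyphenyl. Among the compounds with values here, no measured pair shows what this change does in this assay, so the two values offer little guidance. At most a small shift toward stronger inhibition of growth is expected, with no step beyond the scatter. The expected change is a 1.4-fold lower number from compound 2 to compound 3 (0.15 log units; within the scatter). For compound 3 the estimated value is 25000 nM, with an expected range of 6000 nM to 100000 nM.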

Compound 3, concentration for 50% growth inhibition: 8200 nM
Compound 3: middle estimate off by 3.0-fold (0.48 log units), on the high side; low and high end bracket the measured number.
By their numbers in this assay, from the lowest: compound 3; then compound 2; then compound 1.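

In this assay, methoxy in place of hydrogen on an aromatic carbon, para to a large group, gives a 4.3-fold lower number from compound 2 to compound 3 (0.64 log units; beyond the scatter), so changing phenyl to 4-methoxyphenyl moves the number toward stronger inhibition of growth by more than the scatter. Within the data shown here, the earlier compounds held no pair differing in this one place, so this is the only direct reading of a substituent at this position, and it shows that the position is not indifferent to change. Nothing available explains why the number moves.

Going by these compounds, a single step gives no trend, so it remains open whether an amine, a carboxylic acid or a longer chain such as ethoxy in the same place would lower the number further or raise it. On these data alone, it is also open whether methoxy would give a similar step at another position on this ring.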